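Swapping an ethynyl for an isopropoxy on a weak antiproliferative series

The source may report more compounds than this note shows. Statements on the series, on what has been measured and on what is new or still open speak of the compounds shown alone.

Of the compounds shown here, three built on a shared core have been tested in a functional assay on MCF7 cells (Homo sapiens) for antiproliferative activity; a lower number here means a stronger inhibitor, a higher number a weaker inhibitor. Compound 1 `COc1cc(Cc2nc3c(N)ncnc3n2CC2CCCCC2)cc(OC)c1OC` gives 39800 nM, compound 3 `COc1cc(Cc2nc3c(N)ncnc3n2CC2CCC2)cc(OC)c1OC` gives 45700 nM, and compound 2 `C#CCCn1c(Cc2cc(OC)c(OC)c(OC)c2)nc2c(N)nc(F)nc21` gives 25100 nM. The number for compound 2 is the lowest of the three, yet its gaps to compound 1 and to compound 3 both lie within the usual scatter, so the three cannot be ranked.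

The next compound, compound 4 `COc1cc(Cc2nc3c(N)nc(F)nc3n2CCOC(C)C)cc(OC)c1OC`, differs from compound 2 in one place: isopropoxy in place of ethynyl on a saturated chain carbon, two bonds along the chain from an aromatic nitrogen.

Among the compounds with values here, only one measured step exists, a 1.1-fold higher number from compound 1 to compound 3 (0.06 log units; within the scatter), which exchanges one ring for another on the chain attached to the aromatic nitrogen and changes nothing beyond the scatter. Within the data shown here, no measured pair exchanges an ethynyl for an isopropoxy, so there is no direct precedent. Among the measured compounds shown here, the one step that touches the same chain suggests that variation there leaves this assay largely unmoved, so the step in this assay from compound 2 to compound 4 is expected to stay within the scatter, with no clear direction, as a 1.3-fold higher number from compound 2 to compound 4 (0.11 log units; within the scatter). Compound 4 is therefore estimated at 32000 nM in this assay, within a range from 12000 nM to 85000 nM.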

Compound 4, half-maximal inhibitory concentration: 15800 nM
For compound 4 the middle estimate is 2.0-fold (0.31 log units) above the measured one; the range from low to high includes it.
By their numbers in this assay, from the lowest: compounds 4, 2, 1 and 3 (each within the scatter of the next, the first and the last beyond it).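

In this assay, the swap of ethynyl for isopropoxy gives a 1.6-fold lower number from compound 2 to compound 4 (0.20 log units; within the scatter), so this change on a saturated chain carbon, two bonds along the chain from an aromatic nitrogen, cannot be told apart from repeat-to-repeat variation. The earlier compounds shown here varied only a saturated ring on the chain, whereas this step replaces a triple bond and 2 heavy atoms with 4 heavy atoms that include an oxygen, a hydrogen-bond acceptor, and still produces no readable shift in this assay. Nothing measured here explains why the number stays within the scatter, and a step this small gives little to explain.

Still open, from the compounds shown here alone, is whether any group at this position can move the number beyond the scatter, for example a primary amine, a carboxylic acid or a longer ether chain in place of the 2-isopropoxyethyl. Going by these compounds, it is also open whether isopropoxy would behave the same way on the core of compound 1, which differs from the core of compound 2.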